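The source may hold more compounds than are shown below. What is called first, only, known or untested is meant among the compounds shown, and "the series" means these compounds.

Measured compounds:
compound 1 `Cc1cc(NCc2ccc(F)cc2)n2ncc(-c3ccccn3)c2n1` — 15 nM
compound 2 `N#Cc1ccc(N2CCN(Cc3cn4cc(Cl)ccc4n3)CC2)nc1` — 6250 nM

In a functional assay on CHO cells for agonist activity at G-protein coupled receptor 39 (Homo sapiens), read by calcium flux (a lower number here means that less compound is needed, a higher number that more compound is needed for the effect), compound 1 gives the lower of the two numbers, and compound 2, a different scaffold, gives a number far higher, beyond the scatter. Compound 3 `CNC(=O)C(Nc1cc(C)nc2c(-c3ccccn3)cnn12)c1ccc(F)cc1` keeps the whole of compound 1 and adds (methylcarbamoyl in place of hydrogen on a saturated chain carbon bound to an aromatic carbon and a nitrogen on an aromatic ring). Among the compounds with values here, no step of this kind has been measured here, so the expectation rests on compound 1 alone. The step from compound 1 to compound 3 is expected to be small, a 2.0-fold higher number from compound 1 to compound 3 (0.30 log units; within the scatter), in either direction and likely within the scatter. Compound 3 is estimated at 30 nM, in a range of 5 nM to 200 nM.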

Compound 3, half-maximal effective concentration: 78 nM
Beside the measured number, compound 3's estimate is 2.6-fold (0.41 log units) below it; measured number inside the range.
By their numbers in this assay, from the lowest: compound 1; then compound 3; then compound 2.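

In this assay, methylcarbamoyl in place of hydrogen on the saturated chain carbon gives a 5.2-fold higher number from compound 1 to compound 3 (0.72 log units; beyond the scatter) as a modest step beyond the scatter. This position is therefore not indifferent to substitution, although the effect is still reached with this added group in place. Nothing available here accounts for the rise in the number. The compounds shown leave open whether any substituent on this carbon raises the number or whether this is particular to methylcarbamoyl. A methyl group or a carboxylic acid at the same carbon would separate these two readings.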